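The source may report more compounds than this note shows. Statements on the series, on what has been measured and on what is new or still open speak of the compounds shown alone.

Compound 1 `CCCCOc1ccc(OCc2ccc3ccccc3n2)cc1C1(c2ccccc2)CC2CCC1C2`: > 3000 nM
Compound 2 `c1ccc(COc2ccc(OCc3ccc4ccccc4n3)cc2C2(c3ccccc3)CC3CCC2C3)cc1`: > 3000 nM
Compound 3 `Oc1ccc(OCc2ccc3ccccc3n2)cc1C1(c2ccccc2)CCCC1`: 1920 nM

Going by the values given here, in a functional assay on blood (Homo sapiens) for inhibition (on this read-out lower numbers stand for stronger inhibition and higher numbers for weaker inhibition), compound 3 gives 1920 nM, the only true number so far. Compound 1 reads > 3000 nM, which is a limit. Compound 2 reads > 3000 nM, also a limit.

Compound 4 `COC(=O)COc1ccc(OCc2ccc3ccccc3n2)cc1C1(c2ccccc2)CCCC1` differs from compound 3 in one place: (methoxycarbonyl)methyl in place of hydrogen on an oxygen on an aromatic ring. Among the compounds with values here, the one measured step, a step that the two limits leave unreadable from compound 1 to compound 2, also lies on a group attached through an oxygen on an aromatic ring, but it gives no size. Compound 1 and compound 2, with a different core and a group on that oxygen, both sit at the limit of > 3000 nM in this assay, at which 2 of the 3 values shown sit. This hints at weaker inhibition once the hydrogen is replaced, though only loosely. The expected change is a 1.6-fold higher number from compound 3 to compound 4 (0.19 log units; within the scatter). For compound 4 the estimated value is 3000 nM, with an expected range of 1200 nM to 8000 nM.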

Compound 4, half-maximal inhibitory concentration: 890 nM
Beside the measured number, compound 4's estimate is 3.4-fold (0.53 log units) above it, and the stated range ends above it.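

In this assay, putting (methoxycarbonyl)methyl in place of the hydrogen on this oxygen gives a 2.2-fold lower number from compound 3 to compound 4 (0.33 log units; beyond the scatter). The oxygen on the aromatic ring therefore carries this larger group with stronger inhibition, not weaker. The earlier compounds could not show this, as the step from compound 1 to compound 2 cannot be read and both values are only limits: the limit of > 3000 nM in this assay, at which 2 of the 4 values shown sit.

Going by these compounds, what remains open is whether the ester matters or any group on this oxygen would do. A carboxylic acid, an amide or a plain butyl chain on the same oxygen of this core would help separate these possibilities.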